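From Amide to Methyl Ester: Solubility Expectation

A few compounds are considered here, and "the series" means these few. Any claim that something is new, unique, unknown or untested is made for them only; others in the source may bear on it.

Measured compounds:
compound 1 `COCCOC(=O)c1cc(N)c(Nc2ccc(C#N)cc2)cc1Oc1c(C)cc(/C=C/C#N)cc1C` gives 0.77 ug/mL in a physicochemical assay for solubility, read by HPLC, in phosphate buffer, with a stated time of 4 h, at pH 7.4; on this read-out lower numbers stand for lower solubility and higher numbers for higher solubility
compound 2 `Cc1cc(/C=C/C#N)cc(C)c1Oc1cc(Nc2ccc(C#N)cc2)c(N)cc1C(N)=O` gives 0.63 ug/mL in this assay

Compound 2 and compound 1 lie within the scatter of each other; their only difference was a 1.2-fold lower number from compound 1 to compound 2 (0.09 log units; within the scatter). Compound 3 `COC(=O)c1cc(N)c(Nc2ccc(C#N)cc2)cc1Oc1c(C)cc(/C=C/C#N)cc1C` differs from compound 2 by methoxy in place of amino on a carbonyl carbon. For the measured compounds named here, the one measured step changed the group on this same carbonyl carbon and stayed within the scatter, so in this assay the expected step for compound 3 is a 1.1-fold lower number from compound 2 to compound 3 (0.02 log units; within the scatter), none beyond the scatter. Compound 3 is estimated at 0.6 ug/mL, with a range from 0.2 ug/mL to 1.8 ug/mL.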

Compound 3, solubility: 1.21 ug/mL
The estimate for compound 3 lay 2.0-fold (0.30 log units) below the measured number; the range from low to high includes it.
By their numbers in this assay, from the lowest: compounds 2, 1 and 3 (each within the scatter of the next).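

With compound 3, the carbonyl carbon has now carried three different groups in this assay, and the numbers stay close: methoxy in place of amino gives a 1.9-fold higher number from compound 2 to compound 3 (0.28 log units; within the scatter), while hydrogen in place of methoxymethyl on the ester chain gives a 1.6-fold higher number from compound 1 to compound 3 (0.20 log units; within the scatter). Both new steps lie within the scatter, so the amide and the two esters cannot be put in order. Nothing available here explains the remaining differences among these compounds.

Going by these compounds, whether a carboxylic acid or an ester with a terminal amine on this carbonyl carbon would move the number beyond the scatter remains open.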